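A few compounds are considered here, and "the series" means these few. Any claim that something is new, unique, unknown or untested is made for them only; others in the source may bear on it.

In a functional assay on A549 cells (Homo sapiens) for inhibition, read by MTT assay (on this read-out higher numbers stand for weaker inhibition and lower numbers for stronger inhibition), compound 1 `CCCCCCCCCCn1cc(/C=C/C(=O)c2ccc(NC(=O)CN3CCN(c4ccccc4)CC3)cc2)nn1` gives 52100 nM, and compound 2 `O=C(CN1CCN(c2ccc([N+](=O)[O-])cc2)CC1)Nc1ccc(C(=O)/C=C/c2cn(Cc3ccc(Br)cc3)nn2)cc1` gives 45500 nM; the number for compound 2 is the lower of the two, yet its gap to compound 1 lies within the usual scatter, so neither compound stands apart. Compound 3 `CCCCCCCCCCn1cc(/C=C/C(=O)c2ccc(NC(=O)CN3CCN(c4ccc([N+](=O)[O-])cc4)CC3)cc2)nn1` is compound 2 with a single change: nonyl in place of 4-bromophenyl on a saturated chain carbon bound to an aromatic nitrogen. Because compound 1 already carries the decyl chain and gives 52100 nM, no step beyond the scatter is expected, a 1.1-fold higher number from compound 2 to compound 3 (0.04 log units; within the scatter). Compound 3 is therefore estimated at 50000 nM, with a range from 20000 nM to 120000 nM.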

Compound 3, half-maximal inhibitory concentration: 64500 nM
Beside the measured number, compound 3's estimate is 1.3-fold (0.11 log units) below it; low and high end bracket the measured number.
By their numbers in this assay, from the lowest: compounds 2, 1 and 3 (each within the scatter of the next).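

Compounds 2 and 3 differ in one place, and in this assay nonyl in place of 4-bromophenyl gives a 1.4-fold higher number from compound 2 to compound 3 (0.15 log units; within the scatter), so at this position a chain with no ring and a ring-bearing group cannot be told apart. Compounds 1 and 3 also differ in one place, and nitro in place of hydrogen on an aromatic carbon gives a 1.2-fold higher number from compound 1 to compound 3 (0.09 log units; within the scatter), so this change cannot be told from the scatter either. No measurement here offers an explanation for these numbers. On these data alone, whether an amine or a carboxylic acid in place of the decyl chain would give a step beyond the scatter remains open.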